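A Change in Spatial Arrangement Alone

The source may hold more compounds than are shown below. What is called first, only, known or untested is meant among the compounds shown, and "the series" means these compounds.

Compound 1 (`O=C(Nc1ccccc1)Nc1ccc(-c2nc(N3CC4CCC(C3)O4)c3cnn(C4CCC5(CC4)OCCO5)c3n2)cc1`) – 4 nM
Compound 2 (`CNC(=O)Nc1ccc(-c2nc(N3CC4CCC(C3)O4)c3cnn([C@H]4CC[C@@H](O)CC4)c3n2)cc1`) – 20 nM

Both numbers come from a functional assay on LNCaP cells (Homo sapiens) for cytotoxicity (on this read-out lower numbers stand for stronger inhibition and higher numbers for weaker inhibition), and are the only results so far. On this scale, compound 2 has the higher number of the two, and its gap to compound 1 lies beyond the usual scatter of repeated measurements. These two compounds differ in more than one place, so their gap says little about any single change.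

Compound 3 (`CNC(=O)Nc1ccc(-c2nc(N3CC4CCC(C3)O4)c3cnn([C@H]4CC[C@H](O)CC4)c3n2)cc1`) has the same atoms and bonds as compound 2 and differs only in spatial arrangement (the two compounds have the same atoms and bonds; at least one stereo element is drawn with a configuration in one of them and without one in the other: 2 of 4 stereo elements differ; a stereocentre at a saturated ring carbon is drawn s in compound 2 and r in compound 3; a stereocentre at a saturated ring carbon is drawn s in compound 2 and r in compound 3) with stereocentres at saturated ring carbons drawn s in compound 2 and r in compound 3. A stereocentre is a carbon whose attached groups can be arranged in space in more than one way.

Going by the values given here, no measured pair shows what such a change does here, so neither direction can be favoured. On these data alone, the expected outcome is no shift beyond the scatter, though a wide range stays open. The estimated size of the change is (no change at the digits printed from compound 2 to compound 3 (within the scatter)) in this assay for now. For compound 3 the expected value is 20 nM (estimated range 7 nM to 60 nM).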

Compound 3, half-maximal inhibitory concentration: 20 nM
Compound 3: middle estimate and measured number agree at the digits printed; measured number inside the range.
By their numbers in this assay, from the lowest: compound 1; then compounds 2 and 3 (each within the scatter of the next).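

Going by these compounds alone, for the first time, a pair of compounds differs in one place only, which the gap between compound 1 and compound 2 could not offer. In this assay, the pair gives no change at the digits printed from compound 2 to compound 3 (within the scatter), so the spatial arrangement at these saturated ring carbons does not separate the two compounds on this read-out, and either drawn arrangement goes with a number in the same range. One point about the drawings limits how firmly this can be read: the fact that one of compounds 2 and 3 is drawn with a defined configuration and the other without, at the place where they differ.

The compounds shown leave open whether this indifference to arrangement would hold if the hydroxyl on that saturated ring gave way to another group, such as an amine or a carboxylic acid, since only the hydroxyl has been compared in both arrangements. They also leave open what lies behind the lower number of compound 1, which differs from compound 2 and compound 3 in more than one place, so that no single one of its differences can be credited with the gap.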